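The source may hold more compounds than are shown below. What is called first, only, known or untested is meant among the compounds shown, and "the series" means these compounds.

Compound 1 `N#Cc1ccc(C2CCN(C(=O)Nc3cc(-c4ccccn4)n[nH]3)CC2)cc1`: 25.3 mL.min-1.g-1
Compound 2 `O=C(Nc1cc(-c2ccccn2)n[nH]1)N1CCC(c2ccc(F)cc2)CC1`: 42.5 mL.min-1.g-1
Compound 3 `O=C(Nc1cc(-c2ccccn2)n[nH]1)N1CCC(c2ccccc2)CC1`: 15.3 mL.min-1.g-1

In an ADME assay on liver for metabolic stability, with Liver microsome (Homo sapiens) as the target, using microsomes (on this read-out higher numbers stand for fast clearance and lower numbers for slow clearance), compound 1 stands within the scatter of both other compounds, as a 1.7-fold higher number from compound 1 to compound 2 (0.23 log units; within the scatter) and a 1.7-fold lower number from compound 1 to compound 3 (0.22 log units; within the scatter) show. Only a 2.8-fold lower number from compound 2 to compound 3 (0.44 log units; beyond the scatter) goes beyond it. Compound 4 `O=C(Nc1cc(-c2ccccn2)n[nH]1)N1CCC(c2cccc(Cl)c2)CC1` has not yet been measured. It differs from compound 1 by 3-chlorophenyl in place of 4-cyanophenyl on a saturated ring carbon, in words 3-chlorophenyl in place of 4-cyanophenyl on a saturated ring carbon. Within the data shown here, no measured compound carries chlorine, so the three steps serve only as a guide. Fluoro-bearing compound 2, at 42.5 mL.min-1.g-1, suggests a slight rise at most, so no step beyond the scatter is expected. The expected change is a 1.3-fold higher number from compound 1 to compound 4 (0.13 log units; within the scatter). For compound 4 the estimated value is 34 mL.min-1.g-1, with an expected range of 16 mL.min-1.g-1 to 65 mL.min-1.g-1.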

Compound 4, intrinsic clearance in microsomes: 30.8 mL.min-1.g-1
The estimate for compound 4 lay 1.1-fold (0.04 log units) above the measured number, and the stated range covers the measured number.
By their numbers in this assay, from the lowest: compounds 3, 1, 4 and 2 (each within the scatter of the next, the first and the last beyond it).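

In this assay, chloro on the phenyl group at this saturated ring carbon stays within the scatter, with a 2.0-fold higher number from compound 3 to compound 4 (0.30 log units; within the scatter), whereas the fluoro pair goes beyond it, with a 2.8-fold lower number from compound 2 to compound 3 (0.44 log units; beyond the scatter). The 3-chlorophenyl group also stays within the scatter of the 4-cyanophenyl group, with a 1.2-fold higher number from compound 1 to compound 4 (0.09 log units; within the scatter), and of the 4-fluorophenyl group, with a 1.4-fold lower number from compound 2 to compound 4 (0.14 log units; within the scatter). What remains open is whether an amine or a carboxylic acid on this phenyl group would stay within the scatter of these compounds. Nothing available gives a reason for these numbers.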